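A few compounds are considered here, and "the series" means these few. Any claim that something is new, unique, unknown or untested is made for them only; others in the source may bear on it.

Measured compounds so far:

Compound 1, `C[Si](C)(C)c1ccc2nc(N)sc2c1`, in a functional assay on the whole organism with Rattus norvegicus as the target (a higher number here means that more compound is needed for the effect, a lower number that less compound is needed), gives 5 mg/kg.
Compound 2, `Nc1nc2ccc(C(=O)C(F)(F)F)cc2s1`, in this assay gives only a limit of the assay, > 10 mg/kg.
Compound 3, `N=c1sc2cc(OC(F)(F)F)ccc2n1Cc1ccccc1`, in this assay also gives only a limit of the assay, > 10 mg/kg.

Compound 3 therefore carries no number of its own on this read-out; it sits at the limit of > 10 mg/kg in this assay, at which 2 of the 3 values shown sit, and only compound 1 shows an actual number.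

Compound 4, `C[S+]([O-])CCCn1c(=N)sc2cc(OC(F)(F)F)ccc21`, is the next compound to be tested in this assay. It differs from compound 3 in one place: a group of 5 heavy atoms (3 carbon, 1 oxygen, 1 sulfur; no ring) in place of a group of 6 heavy atoms (6 carbon; one six-membered aromatic ring of carbon only), on a saturated chain carbon bound to an aromatic nitrogen.

Going by the values given here, no pair of measured compounds that differ in a single place is available, so the size of this step cannot be read from the numbers. With compound 3 sitting at a limit rather than a value, there is no footing for expecting a shift beyond the usual scatter in either direction, and the step that the limit leaves unreadable from compound 3 to compound 4 is expected to stay within that scatter. Compound 4 is thus expected to give about 12 mg/kg, with a range from 4 mg/kg to 40 mg/kg, and a fair chance that again only a limit is reported.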

Compound 4, dose for half-maximal effect: 2.3 mg/kg
The estimate for compound 4 lay 5.2-fold (0.72 log units) above the measured number, outside the stated range (below it).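

In this assay, the group on the saturated chain carbon bound to an aromatic nitrogen clearly matters: putting the ring-free group of 5 heavy atoms in place of phenyl gives an at least 4.3-fold lower number from compound 3 to compound 4 (0.63 log units; beyond the scatter), so less compound is needed for the effect. A six-membered aromatic ring of carbon is therefore not required at this place for the effect to appear. The full size of the step remains unknown, since compound 3 gives only a limit of the assay: the limit of > 10 mg/kg in this assay, at which 2 of the 4 values shown sit.

The compounds shown do not tell whether the gain comes from the sulfur and oxygen or simply from the open chain. A plain propyl group, a shorter or longer chain carrying the same sulfur and oxygen, or an amine at the chain end would separate these possibilities.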